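The source may hold more compounds than are shown below. What is called first, only, known or untested is meant among the compounds shown, and "the series" means these compounds.

Series notes. Two compounds of the shared core are measured in a functional assay on MCF7 cells (Homo sapiens) for cytotoxicity, read by colorimetric assay and sulforhodamine B assay, with a stated time of 48 h; on this read-out higher numbers stand for weaker inhibition and lower numbers for stronger inhibition. Compound 1 `Cc1nc2c(cnn2-c2ccccc2)c(=O)n1-c1cnc2ccccc2c1` gives 1530 nM in this assay. Compound 2 `Cc1nc2c(cnn2-c2ccc(Cl)cc2)c(=O)n1/N=C/c1ccccc1` gives 23100 nM in this assay, the higher of the two numbers, and its gap to compound 1 lies beyond the scatter. Among the compounds with values here, no step between these two is set out, so nothing more than the two values themselves can be read from the pair.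

Compound 3 `COc1ccc(/C=N/n2c(C)nc3c(cnn3-c3ccc(Cl)cc3)c2=O)cc1` is not yet measured. It differs from compound 2 by methoxy in place of hydrogen on an aromatic carbon, placed on an aromatic carbon of a six-membered aromatic ring of carbon only, para to a large group. Within the data shown here, no measured pair carries this difference, so there is no measured basis for a direction. The expectation is that the number stays near that of compound 2, within the scatter or only just beyond, so the step of a 1.3-fold lower number from compound 2 to compound 3 (0.11 log units; within the scatter) is an estimate with little support. Compound 3 is expected to give 18000 nM in this assay, with a range from 6000 nM to 50000 nM.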

Compound 3, half-maximal inhibitory concentration: 38600 nM
Estimate against measurement, compound 3: 2.1-fold (0.33 log units) below; the measured number falls inside the stated range.
By their numbers in this assay, from the lowest: compound 1; then compounds 2 and 3 (each within the scatter of the next).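

Within the data shown here, the step of a 1.7-fold higher number from compound 2 to compound 3 (0.22 log units; within the scatter) in this assay is the first single-place comparison, and it concerns methoxy in place of hydrogen on an aromatic carbon of a six-membered aromatic ring of carbon only, para to a large group. Compounds 2 and 3 stand within the scatter of each other, so phenyl to 4-methoxyphenyl gives no readable change in this assay, and this one pair gives no sign that the number at this position responds to the added methoxy. No measurement at hand offers an explanation for this result.

As far as these compounds go, a single substituent on one background cannot show whether the position is generally insensitive, so it remains open whether a dimethylamino group, a carboxylic acid or a longer chain such as butoxy at the same place would carry the number beyond the scatter. Also open, from the compounds shown here alone, is whether methoxy elsewhere on that ring, or the same step with the chlorine of compounds 2 and 3 replaced by hydrogen, would read the same way.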